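From Methylsulfanyl to tert-Butoxy on a Carbonyl Carbon

The compounds below may be only part of what the source reports. "The series", "measured", "known", "first", "only" and "open" are said of these compounds alone.

Compound 1 (`Cc1cn([C@@H]2O[C@H](CO[Si](C)(C)C(C)(C)C)[C@@]3(OS(=O)(=O)C=C3N)[C@H]2O[Si](C)(C)C(C)(C)C)c(=O)n(C(=O)c2ccccc2)c1=O`) and compound 2 (`CSC(=O)CCCC(=O)n1c(=O)c(C)cn([C@@H]2O[C@H](CO[Si](C)(C)C(C)(C)C)[C@@]3(OS(=O)(=O)C=C3N)[C@H]2O[Si](C)(C)C(C)(C)C)c1=O`) share one core and differ in one group on a carbonyl carbon. In an ADME assay on Huh-7 cells (Homo sapiens) for cytotoxicity, with a stated time of 72 h (on this read-out lower numbers stand for higher toxicity in this test and higher numbers for lower toxicity in this test), compound 1 gives > 100000 nM as a limit of the assay. Compound 2 gives > 100000 nM as a limit too, so it has no exact place on the scale. Among the measured compounds shown here, the one measured step is a step that the two limits leave unreadable from compound 1 to compound 2 and offers no size to carry forward. What the two compounds show together is the limit of > 100000 nM in this assay, at which 2 of the 2 values shown sit, and nothing finer.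

Compound 3 (`Cc1cn([C@@H]2O[C@H](CO[Si](C)(C)C(C)(C)C)[C@@]3(OS(=O)(=O)C=C3N)[C@H]2O[Si](C)(C)C(C)(C)C)c(=O)n(C(=O)CCCC(=O)OC(C)(C)C)c1=O`) differs from compound 2 in one place, with tert-butoxy in place of methylsulfanyl on a carbonyl carbon. The expectation rests on compound 2 at > 100000 nM as a limit, with no readable step to suggest a shift. The expected step is a number no higher from compound 2 to compound 3 (the limit leaves the size open) in this assay and no direction can be given, so it is estimated to stay within the scatter, with another limit the likeliest report. For compound 3 the estimated value is 100000 nM with an expected range from 50000 nM to 200000 nM in this estimate.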

Compound 3, half-maximal cytotoxic concentration: > 100000 nM
Compound 3: only a limit was reported (the forecaster's own chance of this, stated with the estimate: 85%); the middle value lies on the limit itself.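

Compound 3 gives > 100000 nM in this assay as a limit of the assay. No new step can be read among compound 1, compound 2 and compound 3. The compounds shown leave open the concentration at which any of them would harm these cells, and whether the groups on the carbonyl carbon differ in this test.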